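Halogen swap on the ethoxyphenyl core: aorta read-out notes

The source may hold more compounds than are shown below. What is called first, only, known or untested is meant among the compounds shown, and "the series" means these compounds.

Measured so far in a functional assay on thoracic aorta (Rattus norvegicus, strain Wistar), with a stated time of 15 min; on this read-out higher numbers stand for an effect only at larger amounts of compound and lower numbers for an effect already at smaller amounts:
compound 1 `CCOc1ccc(F)cc1C(C)NC(=O)N(C)S(=O)(=O)c1ccc(Cl)cc1` gives 24500 nM.
compound 2 `CCOc1ccc(F)cc1C(C)NC(=O)NS(=O)(=O)c1ccccc1` gives > 300000 nM, which is a limit of the assay and not a number.
compound 3 `CCOc1ccc(Br)cc1C(C)NC(=O)N(C)S(=O)(=O)c1ccc(Cl)cc1` gives 55700 nM.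

Compound 1 and compound 3 differ by one change, (bromo in place of fluoro on an aromatic carbon). In this assay this change produced a 2.3-fold higher number from compound 1 to compound 3 (0.36 log units; beyond the scatter). How the core of compound 2 differs from the core of compound 1 is not broken down here.

Compound 4 `CCOc1ccc(Br)cc1C(C)NC(=O)NS(=O)(=O)c1ccccc1` is not yet measured in this assay. It differs from compound 2 by bromo in place of fluoro on an aromatic carbon, the same change at the same place. Compound 2 already sits at the limit of > 300000 nM in this assay, at which 1 of the 3 values shown sits, so a number for compound 4 may again be out of reach. The step expected here is a step that the limit leaves unreadable from compound 2 to compound 4, resting on a 2.3-fold higher number from compound 1 to compound 3 (0.36 log units; beyond the scatter). Compound 4 is therefore estimated at 600000 nM, with a range from 250000 nM to 1500000 nM, and most likely reported as a limit only.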

Compound 4, half-maximal effective concentration: > 300000 nM
Compound 4 ended at the assay's limit; the forecaster's own chance of this, stated with the estimate: 90%; the middle value does not contradict the limit.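

In this assay no step can be read from compound 2 to compound 4, because both stand at a limit of the assay and not at a number: the limit of > 300000 nM in this assay, at which 2 of the 4 values shown sit.

On these data alone, whether bromo in place of fluoro on an aromatic carbon shifts the read-out for compound 2 and compound 4, as it does for compound 1 and compound 3, stays open.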